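The source may report more compounds than this note shows. Statements on the series, on what has been measured and on what is new or still open speak of the compounds shown alone.

Compound 1 `Cc1cc(-c2ccccc2)nnc1NCCN`: > 30 mg/kg
Compound 2 `Cc1cc(-c2ccccc2)nnc1NC(C)CN`: > 30 mg/kg

In a functional assay on the whole organism for positive allosteric modulation, with Mus musculus as the target (on this read-out higher numbers stand for an effect only at larger amounts of compound and lower numbers for an effect already at smaller amounts), compound 2 gives > 30 mg/kg, which is a limit and not a number. Compound 1 gives > 30 mg/kg, likewise a limit. Both compounds share one ceiling: the limit of > 30 mg/kg in this assay, at which 2 of the 2 values shown sit. Compound 3 `Cc1cc(-c2ccccc2)nnc1NCCCCN` carries 4-aminobutyl in place of 1-(aminomethyl)ethyl on a nitrogen on an aromatic ring. Within the data shown here, the only measured step, a step that the two limits leave unreadable from compound 1 to compound 2, bears on this change only loosely and offers no size to carry over. So no clear step in either direction is expected in this assay. The expected step is a step that the limit leaves unreadable from compound 2 to compound 3. Compound 3 is estimated at 40 mg/kg, with an expected range of 12 mg/kg to 100 mg/kg.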

Compound 3, dose for half-maximal effect: > 30 mg/kg
Compound 3 gave a limit, no number (the forecaster's own chance of this, stated with the estimate: 75%); the middle value lies beyond the limit too.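

In this assay no new step can be read among compound 1, compound 2 and compound 3, which all sit at one shared limit: the limit of > 30 mg/kg in this assay, at which 3 of the 3 values shown sit. The compounds shown leave open how far any of these chains lies from that limit.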